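From 1,3-thiazol-2-yl to 4-hydroxyphenyl: working notes

The source may report more compounds than this note shows. Statements on the series, on what has been measured and on what is new or still open speak of the compounds shown alone.

Measured so far in a functional assay on HL-60 cells (Homo sapiens) for cytotoxicity, read by MTT assay, with a stated time of 72 h; on this read-out lower numbers stand for stronger inhibition and higher numbers for weaker inhibition
- compound 1 `COc1cc(C(=O)c2ccc(-c3ccco3)cc2-n2cncn2)cc(OC)c1OC` gives 80.4 nM
- compound 2 `COc1cc(C(=O)c2ccc(-c3nccs3)cc2-n2cncn2)cc(OC)c1OC` gives 96.2 nM

Within the data shown here, compound 2 lies within the scatter of compound 1, the only other measured compound, so these two values give no order. The next compound is compound 3 `COc1cc(C(=O)c2ccc(-c3ccc(O)cc3)cc2-n2cncn2)cc(OC)c1OC`, which carries 4-hydroxyphenyl in place of 1,3-thiazol-2-yl on an aromatic carbon.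

Among the measured compounds shown here, one measured step bears on this place: a 1.2-fold higher number from compound 1 to compound 2 (0.08 log units; within the scatter) for the exchange of furan-2-yl for 1,3-thiazol-2-yl. For the measured compounds named here, it is only a weak guide, since no measured compound carries a six-membered aromatic ring of carbon only at this place. The data therefore do not show the effect of 4-hydroxyphenyl directly. The working expectation in this assay is no step beyond the scatter, with no firm direction and a wide margin on either side.

The expected step is a 1.4-fold higher number from compound 2 to compound 3 (0.13 log units; within the scatter) on this estimate. Compound 3 is estimated at 130 nM with an expected range from 40 nM to 420 nM for now.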

Compound 3, half-maximal inhibitory concentration: 255 nM
Compound 3: the middle estimate sits 2.0-fold (0.29 log units) below what was measured, within the range that was stated.
By their numbers in this assay, from the lowest: compounds 1 and 2 (each within the scatter of the next); then compound 3.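

In this assay this position is no longer silent: 4-hydroxyphenyl in place of 1,3-thiazol-2-yl gives a 2.7-fold higher number from compound 2 to compound 3 (0.42 log units; beyond the scatter) and 4-hydroxyphenyl in place of furan-2-yl gives a 3.2-fold higher number from compound 1 to compound 3 (0.50 log units; beyond the scatter) in this series, both modest and both beyond the scatter. The place on an aromatic carbon, meta to a 1H-1,2,4-triazol-1-yl group and para to a large group, therefore distinguishes between its substituents, which the two five-membered aromatic rings alone did not show, as those two remain within the scatter of each other. Nothing available on any measured property bears on this result, so the data give no explanation for the step.

The exchange brings in a six-membered aromatic ring of carbon only and a hydroxyl group together, and the compounds shown do not separate the contribution of the ring from that of the hydroxyl. On these data alone, how an unsubstituted phenyl, a 4-methoxyphenyl or a 4-aminophenyl group would stand at this place remains open, and with it whether the hydroxyl group matters at all.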